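A few compounds are considered here, and "the series" means these few. Any claim that something is new, unique, unknown or untested is made for them only; others in the source may bear on it.

Measured so far in an in vivo ADME assay on the whole organism (plasma) for pharmacokinetics, with Rattus norvegicus as the target, at a dose of 5 mg/kg by the intravenous route; on this read-out lower numbers stand for slow clearance and higher numbers for fast clearance:
compound 1 `CCC(CSC(CCc1ccccc1C#N)c1cccc(CCc2ccc3ccc(Cl)cc3n2)c1)C(=O)O` gives 13 mL/min/kg
compound 2 `CC(CSC(CCc1ccccc1[N+](=O)[O-])c1cccc(OCc2ccc3ccc(Cl)cc3n2)c1)C(=O)O` gives 12 mL/min/kg
compound 3 `O=C(O)CCSC(CCc1ccccc1-c1nc[nH]n1)c1cccc(OCc2ccc3ccc(Cl)cc3n2)c1` gives 64 mL/min/kg

Compound 3 stands highest of the three numbers in this assay. Its nearest neighbour is compound 1, whose number is lower by a gap beyond the scatter; compound 2 is the furthest, also lower by a gap beyond the scatter. Compounds 1 and 2 themselves lie within the scatter of each other, so no order is read between them. Among the measured compounds shown here, no pair among the measured compounds differs in one place only, so no single structural step has been followed in this assay yet.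

Compound 4 `CS(=O)(=O)Nc1ccccc1CCC(SCCC(=O)O)c1cccc(OCc2ccc3ccc(Cl)cc3n2)c1` is next for this assay. Against compound 3 the difference is methanesulfonamido in place of 1H-1,2,4-triazol-3-yl on an aromatic carbon. The change sits on an aromatic carbon of a six-membered aromatic ring of carbon only, ortho to a large group; nothing else in the molecule moves.

For the measured compounds named here, with no measured step of this kind at hand, the expectation rests on compound 3 alone. Compound 4 is expected to show a step from a 1.6-fold lower number from compound 3 to compound 4 (0.20 log units; within the scatter) that is downward and of about the size of the scatter, not more. The estimate for compound 4 in this assay is 40 mL/min/kg, with a range from 15 mL/min/kg to 90 mL/min/kg.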

Compound 4, clearance: 131 mL/min/kg
Estimate against measurement, compound 4: 3.3-fold (0.52 log units) below; measured number outside the range, above it.
By their numbers in this assay, from the lowest: compounds 2 and 1 (each within the scatter of the next); then compound 3; then compound 4.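

In this assay, among the compounds shown here, methanesulfonamido in place of 1H-1,2,4-triazol-3-yl on an aromatic carbon, ortho to a large group, gives a 2.0-fold higher number from compound 3 to compound 4 (0.31 log units; beyond the scatter): this is the first single-place step, and it is modest. The group that leaves and the group that enters have the same counts of heavy atoms, hydrogen-bond donors and hydrogen-bond acceptors, and neither carries a net charge, so the read-out at this position changes even with those counts held constant; the printed differences that remain are the atoms themselves and the loss of the ring. Nothing measured on these compounds bears on what lies behind the step.

Compound 1 and compound 2 differ from compound 4 in more than one place, so steps to them cannot be read and their lower numbers cannot be assigned to this position. On these data alone, it remains open whether an amine or an acetamido group at this same position would raise the number further or lower it, and whether the step holds on a core with a longer carboxylic acid chain.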